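Methoxy added on the fused ring of compound 1

This account rests on a few compounds, and the source may have more. Where it says the series, first, only, none or still open, it means among the compounds named here.

Compound 1 `COc1ccc(/C(Cl)=C/C=C(\C#N)C(=O)c2c[nH]c3ccccc23)cc1` was tested in a functional assay for inhibition, with a stated time of 5 min, tested at 1 mM (a higher number here means more inhibition at the concentration tested (going by the name of the read-out), a lower number less inhibition), and gave 61.3%. Two close relatives were measured alongside it. Compound 2 `COc1ccc(/C(Cl)=C/C=C(\C#N)C(=O)c2c(C)[nH]c3ccccc23)cc1` gave 63.1%, and compound 3 `COc1ccc(/C(Cl)=C/C=C(\C#N)C(=O)c2c[nH]c3ccccc23)cc1OC` gave 63.6%. Compound 1 stands within the scatter of both: a number 1.8 percentage points higher from compound 1 to compound 2 (within the scatter), and a number 2.3 percentage points higher from compound 1 to compound 3 (within the scatter). Neither a methyl nor a methoxy placed on an aromatic carbon of the shared core moved the number beyond the usual run of repeated measurements.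

Compound 4 `COc1ccc(/C(Cl)=C/C=C(\C#N)C(=O)c2c[nH]c3ccc(OC)cc23)cc1` carries a different change from compound 1: methoxy in place of hydrogen on an aromatic carbon. The step from compound 1 to compound 3 bears on it most directly, since it also enters a methoxy on an aromatic carbon, and the step from compound 1 to compound 2 is of the same small kind. Both lie within the scatter, so no step beyond the scatter is expected for compound 4. The expected value for compound 4 is 63%, between 50% and 75%, which is a step of a number 1.7 percentage points higher from compound 1 to compound 4 (within the scatter).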

Compound 4, a percentage reported as inhibition, at one concentration (the size of the read-out at that concentration, not a potency): 60.7%
The estimate for compound 4 lay 2.3 percentage points above the measured number, and the stated range covers the measured number.
By their numbers in this assay, from the lowest: compounds 4, 1, 2 and 3 (each within the scatter of the next).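

In this assay, methoxy in place of hydrogen on an aromatic carbon of the six-membered aromatic ring of carbon only, part of a fused or bridged system of two rings, gives a number 0.6 percentage points lower from compound 1 to compound 4 (within the scatter). Within the data shown here, the earlier compounds carried their changes elsewhere on the shared core, so this is the first sign that this position takes a methoxy with the number staying within the scatter. Nothing shown here offers any measured account of this result.

On these data alone, whether an amine, a carboxylic acid or a longer chain such as butoxy at this same position would also stay within the scatter remains open. The numbers shown come from a single concentration, so how potency changes with methoxy at this position also remains open.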